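Replacing a Pyrrolidine Amide with Fluorine: a Clearance Outlook

A few compounds are considered here, and "the series" means these few. Any claim that something is new, unique, unknown or untested is made for them only; others in the source may bear on it.

Compound 1 `CN(C)C(=O)CN1CCC(c2cc3c(-c4ccc(=O)n(C5CCC5)c4)ccnc3[nH]2)CC1`: in an ADME assay on microsomes from liver (Homo sapiens) for metabolic stability (a higher number here means faster removal of the compound, a lower number slower removal), compound 1 gives < 3 uL/min, which is a limit of the assay rather than a number.
Compound 2 `CC(C)n1nc(-c2ccnc3[nH]c(C4CCN(CC(=O)N(C)C)CC4)cc23)ccc1=O`: in this assay compound 2 gives 13 uL/min.
Compound 3 `COc1cc(C(=O)N2CCCC2)ccc1-c1ccnc2[nH]c(C3CCOCC3)cc12`: in this assay compound 3 gives 74 uL/min.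

Of the two numbers actually read out, compound 3 stands highest, and its gap to compound 2 lies beyond the usual scatter of the measurement. Compound 1 sits at a limit of this assay, as noted at the limit of < 3 uL/min in this assay, at which 1 of the 3 values shown sits, so no number is available for it.

Compound 4 `COc1cc(F)ccc1-c1ccnc2[nH]c(C3CCOCC3)cc12` has not yet been measured. It differs from compound 3 in one place: fluoro in place of (pyrrolidin-1-yl)carbonyl on an aromatic carbon. Among the measured compounds shown here, no pair of measured compounds differs in a single place, so there is no measured step to show how large a change of this kind is in this assay. The expectation is a moderate fall in clearance from compound 3 to compound 4, with the change a 1.6-fold lower number from compound 3 to compound 4 (0.22 log units; within the scatter) estimated as a step in that direction but not a large one. Compound 4 is therefore expected to give about 45 uL/min in this assay, within a range from 15 uL/min to 120 uL/min.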

Compound 4, intrinsic clearance in a liver preparation (reported as CLH), per the amount of preparation that the assay uses: 10 uL/min
Beside the measured number, compound 4's estimate is 4.5-fold (0.65 log units) above it, outside the stated range (below it).
By their numbers in this assay, from the lowest: compounds 4 and 2 (each within the scatter of the next); then compound 3. At a limit, below all of these: compound 1.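

Among the compounds shown here, this is the first measured step in the set that changes only one place: fluoro in place of (pyrrolidin-1-yl)carbonyl, on an aromatic carbon meta to a methoxy group, gives a 7.4-fold lower number from compound 3 to compound 4 (0.87 log units; beyond the scatter) in this assay. The number read out in this assay therefore depends strongly on what stands at this position, at least for this pair of compounds. The change removes a carbonyl, a five-membered ring and 7 heavy atoms together and brings in a single fluorine, and nothing shown here gives a reason for the size of the step.

Going by these compounds, it remains open whether a chlorine, a nitrile or a plain hydrogen at this place would give a similar step, or whether a smaller amide such as a dimethyl amide would stay closer to compound 3. One step also cannot show whether fluoro would have the same effect on another core.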